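Dimethoxy-tetralin acetic acid amides: step to ethylamide

The compounds below may be only part of what the source reports. "The series", "measured", "known", "first", "only" and "open" are said of these compounds alone.

Measured compounds:
Compound 1 `COc1cc2c(cc1OC)C(CC(=O)O)CC2` — in a functional assay on the whole organism (strain Wistar) for inhibition, with Rattus norvegicus as the target, read by paw edema, with stated times of 60 min and 24 h, at a dose of 100 mg/kg by the oral route (on this read-out lower numbers stand for less inhibition and higher numbers for more inhibition at the one dose given (going by the name of the read-out)), compound 1 gives 26.7%.
Compound 2 `CNC(=O)CC1CCc2cc(OC)c(OC)cc21` — compound 2 gives 33.3%.
Compound 3 `COc1cc2c(cc1OC)C(CC(=O)N(C)C)CC2` — compound 3 gives 23.3%.

All three share one core and differ only at the carbonyl carbon of the side chain. The steps among them are small: a number 6.6 percentage points higher from compound 1 to compound 2 (within the scatter), a number 3.4 percentage points lower from compound 1 to compound 3 (within the scatter) and a number 10 percentage points lower from compound 2 to compound 3 (within the scatter), none beyond the scatter. Compound 3 therefore stands within the scatter of both compound 1 and compound 2, and no ranking among the three can be read from these numbers.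

Compound 4 `CCNC(=O)CC1CCc2cc(OC)c(OC)cc21` is not yet measured. Against compound 3 it differs as follows: ethylamino in place of dimethylamino on a carbonyl carbon. The step nearest in kind is that from compound 2 to compound 3, where methyl in place of hydrogen on the amide-type nitrogen gave a number 10 percentage points lower from compound 2 to compound 3 (within the scatter); the exchange of hydroxy for methylamino or dimethylamino likewise stayed inside the scatter. An amide with one hydrogen on nitrogen again is expected to sit among these three figures, so for compound 4 the expected step is a number 6.7 percentage points higher from compound 3 to compound 4 (within the scatter), not beyond the scatter. Compound 4 is estimated at 30%, within 15% to 45%.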

Compound 4, a percentage reported as inhibition, in the whole organism at one dose (the size of the read-out at that dose, not a potency): 33.3%
Estimate against measurement, compound 4: 3.3 percentage points below; measured number inside the range.
By their numbers in this assay, from the lowest: compounds 3, 1, 2 and 4 (each within the scatter of the next).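

In this assay, the three new steps are a number 10 percentage points higher from compound 3 to compound 4 (within the scatter), no change at the digits printed from compound 2 to compound 4 (within the scatter) and a number 6.6 percentage points higher from compound 1 to compound 4 (within the scatter), so ethylamino on this carbonyl carbon stands apart from neither dimethylamino, methylamino nor hydroxy. The swap from dimethylamino, with no hydrogen-bond donor, to ethylamino, with one, therefore opens no gap beyond the scatter, and methyl in place of hydrogen on the saturated chain carbon bound to the amide-type nitrogen gives the same printed figure. No measurement shown offers any explanation for these steps.

Still open, on these data alone, is whether unsubstituted amino, propylamino or benzylamino on this carbonyl carbon would move the read-out beyond the scatter. Figures at the one dose also leave open how these amides compare at other doses.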